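Hexylsulfanyl to pentyloxy at the cytotoxicity limit

The source may hold more compounds than are shown below. What is called first, only, known or untested is meant among the compounds shown, and "the series" means these compounds.

In an ADME assay on HFF cells (Homo sapiens) for cytotoxicity, with a stated time of 8 days (a lower number here means that less compound is tolerated, a higher number that more compound is tolerated), compound 3 (`CCCCCCSc1nc(N)nc2c1ncn2/C=C1/CC1(CO)CO`) gives > 300000 nM as a limit and not a number. Compound 1 (`CC(C)Nc1nc(N)nc2c1ncn2/C=C1/CC1(CO)CO`) gives > 300000 nM as a limit. Compound 2 (`CCCNc1nc(N)nc2c1ncn2/C=C1/CC1(CO)CO`) gives > 300000 nM as a limit. The whole set is summed up by the limit of > 300000 nM in this assay, at which 3 of the 3 values shown sit, so compound 3 stands level with the others only in the sense that none has a readable value.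

Compound 4 (`CCCCCOc1nc(N)nc2c1ncn2/C=C1/CC1(CO)CO`) carries pentyloxy in place of hexylsulfanyl on an aromatic carbon of the shared core. The nearest guides change the group on that same carbon: a step that the two limits leave unreadable from compound 1 to compound 3 and a step that the two limits leave unreadable from compound 2 to compound 3 are the two cases. The remaining case is a step that the two limits leave unreadable from compound 1 to compound 2 for the group on nitrogen. None has a readable size, so in this assay no step beyond the scatter and no direction is expected. The expected outcome is a number no higher from compound 3 to compound 4 (the limit leaves the size open) and a further limit reading is likely. For compound 4 the estimated half-maximal cytotoxic concentration is 300000 nM with an expected range of 150000 nM to 400000 nM as its span.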

Compound 4, half-maximal cytotoxic concentration: 259000 nM
Compound 4: middle estimate off by 1.2-fold (0.06 log units), on the high side; measured number inside the range.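

In this assay compound 4 gives 259000 nM, the only readable number among the compounds shown, and this gives the position on the aromatic carbon its first value that is not a limit: the limit of > 300000 nM in this assay, at which 3 of the 4 values shown sit.

The change itself stays small on this evidence, with an at least 1.1-fold lower number from compound 3 to compound 4 (0.06 log units; that floor lies within the scatter), an at least 1.1-fold lower number from compound 2 to compound 4 (0.06 log units; that floor lies within the scatter) and an at least 1.1-fold lower number from compound 1 to compound 4 (0.06 log units; that floor lies within the scatter), each known only as a floor. The steps among compound 1, compound 2 and compound 3 cannot be read.

Pentyloxy differs from hexylsulfanyl in both the linking atom and the chain, so the compounds shown leave open which of the two goes with the readable number. Hexyloxy or pentylsulfanyl on the same carbon would separate them, and a longer chain such as octyloxy would show whether the number falls further.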